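A pyridine for a phenyl on the benzylamino arm

The source may report more compounds than this note shows. Statements on the series, on what has been measured and on what is new or still open speak of the compounds shown alone.

In an ADME assay on L02 cells (Homo sapiens) for cytotoxicity, read by MTT assay (a lower number here means a stronger inhibitor, a higher number a weaker inhibitor), compound 2 `COc1cc(/C=C/c2nc(NCc3ccccc3)c3sccc3n2)cc(OC)c1OC` gives 1800000 nM, and compound 1 `COc1cc(/C=C/c2nc(Nc3ccc(O)cc3)c3sccc3n2)cc(OC)c1OC` gives 2300000 nM; the step of a 1.3-fold lower number from compound 1 to compound 2 (0.11 log units; within the scatter) lies within the scatter, so the two numbers stand together rather than apart. Compound 3 `COc1cc(/C=C/c2nc(NCc3ccncc3)c3sccc3n2)cc(OC)c1OC` differs from compound 2 by pyridin-4-yl in place of phenyl on a saturated chain carbon bound to a nitrogen on an aromatic ring. Among the measured compounds shown here, the only measured step concerns a different exchange, so no measured step bears directly on this one, and the expected step of no change at the digits printed from compound 2 to compound 3 (within the scatter) is none beyond the scatter. Compound 3 is therefore expected to give 1800000 nM. For compound 3 the estimated range runs from 900000 nM to 3600000 nM.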

Compound 3, half-maximal inhibitory concentration: 374000 nM
Compound 3: middle estimate off by 4.8-fold (0.68 log units), on the high side; the whole stated range lies above it.
By their numbers in this assay, from the lowest: compound 3; then compounds 2 and 1 (each within the scatter of the next).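

In this assay, a single ring carbon exchanged for nitrogen on the benzylamino arm, pyridin-4-yl in place of phenyl, gives a 4.8-fold lower number from compound 2 to compound 3 (0.68 log units; beyond the scatter). The earlier pair showed no step beyond the scatter, whereas (pyridin-4-yl)methyl in place of 4-hydroxyphenyl on the same nitrogen also gives one, a 6.1-fold lower number from compound 1 to compound 3 (0.79 log units; beyond the scatter). Nothing measured here explains the drop. The compounds shown leave open whether pyridin-3-yl or pyridin-2-yl on the same saturated chain carbon would give a similar step, and whether a piperidin-4-yl ring would do so.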